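Amine variation at the propoxy terminus of a quinoline urea

This account rests on a few compounds, and the source may have more. Where it says the series, first, only, none or still open, it means among the compounds named here.

Two compounds sharing one core differ only in the amine at the end of the chain on the aromatic ether. Compound 1 `COc1cc2c(Oc3c(F)cc(NC(=O)NN4C(=O)CSC4c4c(F)cccc4F)cc3F)ccnc2cc1OCCCN1CCC(C)CC1` gives 3830 nM in a functional assay on MDA-MB-231 cells (Homo sapiens) for antiproliferative activity, read by MTT assay, with a stated time of 72 h; a lower number here means a stronger inhibitor, a higher number a weaker inhibitor. Compound 2 `CCN(CC)CCCOc1cc2nccc(Oc3c(F)cc(NC(=O)NN4C(=O)CSC4c4c(F)cccc4F)cc3F)c2cc1OC` gives 3790 nM in this assay, the lower of the two numbers, though the step of a 1.0-fold lower number from compound 1 to compound 2 (0.00 log units; within the scatter) places the two within the scatter. Compound 3 `COc1cc2c(Oc3c(F)cc(NC(=O)NN4C(=O)CSC4c4c(F)cccc4F)cc3F)ccnc2cc1OCCCN1CCC(N2CCCCC2)CC1` carries the change (4-(piperidin-1-yl)piperidin-1-yl in place of diethylamino on a saturated chain carbon, three bonds along the chain from an oxygen on an aromatic ring). Within the data shown here, the only step that bears on this change is the one from compound 1 to compound 2, which exchanged one amine for another at the same site and moved the number hardly at all, with a 1.0-fold lower number from compound 1 to compound 2 (0.00 log units; within the scatter). On that basis the new amine of compound 3 is expected to leave the number close to where compound 2 stands, so the step of a 1.1-fold lower number from compound 2 to compound 3 (0.03 log units; within the scatter) is expected to fall within the scatter. Compound 3 is therefore estimated at 3500 nM in this assay, with a range from 1400 nM to 9000 nM.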

Compound 3, half-maximal inhibitory concentration: 5380 nM
Beside the measured number, compound 3's estimate is 1.5-fold (0.19 log units) below it; measured number inside the range.
By their numbers in this assay, from the lowest: compounds 2, 1 and 3 (each within the scatter of the next).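

In this assay, compound 3 extends the amine series to a much larger group: 4-(piperidin-1-yl)piperidin-1-yl, with 12 heavy atoms, 2 nitrogens and 2 six-membered non-aromatic rings, replaces diethylamino, with 5 heavy atoms and no ring, and the result is a 1.4-fold higher number from compound 2 to compound 3 (0.15 log units; within the scatter). Placing piperidin-1-yl in place of methyl on a saturated ring carbon gives a 1.4-fold higher number from compound 1 to compound 3 (0.15 log units; within the scatter), so this addition to the ring of compound 1 also stays within the scatter, and the three amines at the end of the chain cannot be told apart in this read-out. No measurement here offers an explanation for this result.

From the compounds shown here alone, all three compounds share the same core and chain, so the effect of a longer chain remains open. Going by these compounds, it is also open whether morpholine or a carboxylic acid at the chain end would give a step beyond the scatter.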